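Fluorophenylpropyl chain in place of cyanophenylethoxy

A few compounds are considered here, and "the series" means these few. Any claim that something is new, unique, unknown or untested is made for them only; others in the source may bear on it.

Three analogues of one shared core were examined in a toxicity assay on MT2 cells (Homo sapiens) for cytotoxicity, read by XTT assay, with a stated time of 4 days; on this read-out lower numbers stand for higher toxicity in this test and higher numbers for lower toxicity in this test. For compound 1 `Cc1nc(C)c([C@H](OC(C)(C)C)C(=O)O)c(N2CCC(C)(C)CC2)c1-c1ccc(-c2ccccc2)cc1` the read-out is a limit of the assay, >= 20000 nM. For compound 2 `Cc1nc(C)c([C@H](OC(C)(C)C)C(=O)O)c(N2CCC(C)(C)CC2)c1-c1ccc(OCCc2ccc(C#N)cc2)cc1` the read-out is likewise a limit, >= 33500 nM. For compound 3 `Cc1nc(C)c([C@H](OC(C)(C)C)C(=O)O)c(N2CCC(C)(C)CC2)c1-c1ccc(OCCc2cc(F)ccc2F)cc1` the read-out is again a limit, >= 33500 nM. The values sit at the limit of >= 33500 nM in this assay, at which 2 of the 3 values shown sit, and at the limit of >= 20000 nM in this assay, at which 1 of the 3 values shown sits, so the steps a step that the two limits leave unreadable from compound 1 to compound 2, a step that the two limits leave unreadable from compound 1 to compound 3 and a step that the two limits leave unreadable from compound 2 to compound 3 cannot be sized. Compound 4 `Cc1nc(C)c([C@H](OC(C)(C)C)C(=O)O)c(N2CCC(C)(C)CC2)c1-c1ccc(CCCc2ccc(F)cc2)cc1` differs from compound 2 by 3-(4-fluorophenyl)propyl in place of 2-(4-cyanophenyl)ethoxy on an aromatic carbon. Going by the values given here, no measured step gives a readable size for such a change, so in this assay no step beyond the scatter is expected for compound 4, with a number no higher from compound 2 to compound 4 (the limit leaves the size open). Compound 4 is therefore estimated at 33500 nM, in the range 15000 nM to 100000 nM, and most probably reported once more only as a limit.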

Compound 4, half-maximal cytotoxic concentration: >= 32000 nM
Compound 4: only a limit was reported; the forecaster's own chance of this, stated with the estimate: 80%; the middle value is on the limit's open side.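

In this assay compound 4 gives >= 32000 nM, which is a limit. Going by these compounds alone, no step from compound 1, compound 2 or compound 3 to compound 4 can be read. The compounds shown leave open the concentration at which any of them reaches half-maximal cytotoxicity.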